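Spiro-isoxazoline analogues on prostate cancer cells: nitrile variant

The compounds below may be only part of what the source reports. "The series", "measured", "known", "first", "only" and "open" are said of these compounds alone.

Compound 1 `C[C@H]1CC[C@@H]2[C@@H](OC(=O)[C@]23CC(c2ccccc2Br)=NO3)[C@]2(C)C(=O)C=C[C@@]12O` gives 18000 nM in a functional assay on DU-145 cells (Homo sapiens) for cytotoxicity, read by sulforhodamine B assay, with a stated time of 48 h; on this read-out lower numbers stand for stronger inhibition and higher numbers for weaker inhibition.
Compound 2 `C[C@H]1CC[C@@H]2[C@@H](OC(=O)[C@]23CC(c2ccccc2[N+](=O)[O-])=NO3)[C@]2(C)C(=O)C=C[C@@]12O` gives 34000 nM in this assay.
Compound 3 `C[C@H]1CC[C@@H]2[C@@H](OC(=O)[C@]23CC(c2ccc([N+](=O)[O-])cc2)=NO3)[C@]2(C)C(=O)C=C[C@@]12O` gives 7000 nM in this assay.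

Among these three numbers compound 1 stands second highest; its nearest neighbour is compound 2, with a 1.9-fold higher number from compound 1 to compound 2 (0.28 log units; within the scatter), and its furthest is compound 3, with a 2.6-fold lower number from compound 1 to compound 3 (0.41 log units; beyond the scatter). Compound 4 `C[C@H]1CC[C@@H]2[C@@H](OC(=O)[C@]23CC(c2ccc(C#N)cc2)=NO3)[C@]2(C)C(=O)C=C[C@@]12O` is not yet measured. It differs from compound 1 in one place: 4-cyanophenyl in place of 2-bromophenyl on a carbon with a double bond to nitrogen. Going by the values given here, the step that bears most on this change is the one from compound 1 to compound 3, where a group on the same aromatic position replaced the 2-bromophenyl and gave a modest lower number; the step of a 4.9-fold lower number from compound 2 to compound 3 (0.69 log units; beyond the scatter) points the same way. A modest lower number is therefore expected for compound 4 in this assay, namely a 2.0-fold lower number from compound 1 to compound 4 (0.30 log units; within the scatter). The estimate for compound 4 is 9000 nM, with a range from 4000 nM to 22000 nM.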

Compound 4, half-maximal inhibitory concentration: 26000 nM
Estimate against measurement, compound 4: 2.9-fold (0.46 log units) below; measured number outside the range, above it.
By their numbers in this assay, from the lowest: compound 3; then compounds 1, 4 and 2 (each within the scatter of the next).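

In this assay, the step of a 3.7-fold higher number from compound 3 to compound 4 (0.57 log units; beyond the scatter) shows that the lower number of compound 3 does not carry over from 4-nitrophenyl to 4-cyanophenyl at this place. The steps of a 1.4-fold higher number from compound 1 to compound 4 (0.16 log units; within the scatter) and a 1.3-fold lower number from compound 2 to compound 4 (0.12 log units; within the scatter) show that 4-cyanophenyl is not separated from either 2-bromophenyl or 2-nitrophenyl. Nothing available explains why nitro and cyano differ here. Going by these compounds, it remains open whether an amine or a carboxylic acid in place of the nitro group of compound 3 would keep its lower number.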